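A few compounds are considered here, and "the series" means these few. Any claim that something is new, unique, unknown or untested is made for them only; others in the source may bear on it.

Compound 2, `Cc1c(C(=O)O)oc2ccc(N(Cc3ccccc3)S(=O)(=O)c3ccc(Cl)cc3)cc12`, gives 33400 nM in a functional assay on HCT-116 cells (Homo sapiens) for inhibition, read by MTT assay, with a stated time of 72 h; a higher number here means a weaker inhibitor, a lower number a stronger inhibitor. That number is the highest of the three measured, but each of its neighbours lies within the scatter of it: compound 1, `CCOC(=O)c1oc2ccc(N(Cc3ccccc3)S(=O)(=O)c3ccc(Cl)cc3)cc2c1C`, gives 23200 nM in this assay, and compound 3, `Cc1c(C(=O)O)oc2ccc(N(Cc3ccc(Cl)cc3)S(=O)(=O)c3ccc(Cl)cc3)cc12`, gives 27200 nM. The step from a 1.4-fold higher number from compound 1 to compound 2 (0.16 log units; within the scatter) and the step from a 1.2-fold lower number from compound 2 to compound 3 (0.09 log units; within the scatter) are therefore both too small to count as real changes. Compound 4, `Cc1c(C(=O)NCCCn2ccnc2)oc2ccc(N(Cc3ccccc3)S(=O)(=O)c3ccc(Cl)cc3)cc12`, differs from compound 2 by (3-(1H-imidazol-1-yl)propyl)amino in place of hydroxy on a carbonyl carbon. Among the compounds with values here, neither measured step touches the carbonyl carbon in this way, so there is no direct guide; the only step at the carbonyl group, the one from compound 1 to compound 2, was within the scatter, and the whole measured set sits in a narrow band. On that basis compound 4 is expected to show a step of a 1.7-fold lower number from compound 2 to compound 4 (0.22 log units; within the scatter) from compound 2, which is not clearly beyond the scatter. The estimate for compound 4 in this assay is 20000 nM, with a range from 5000 nM to 60000 nM.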

Compound 4, half-maximal inhibitory concentration: 5000 nM
Beside the measured number, compound 4's estimate is 4.0-fold (0.60 log units) above it; measured number inside the range.
By their numbers in this assay, from the lowest: compound 4; then compounds 1, 3 and 2 (each within the scatter of the next).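

At the carbonyl carbon, the earlier swap of ethoxy for hydroxy stayed within the scatter, whereas (3-(1H-imidazol-1-yl)propyl)amino in place of hydroxy gives a 6.7-fold lower number from compound 2 to compound 4 (0.82 log units; beyond the scatter) in this assay, and in place of ethoxy gives a 4.6-fold lower number from compound 1 to compound 4 (0.67 log units; beyond the scatter). This position therefore does respond to what is placed on it, although both steps are modest and the series has so far shown only this one change beyond the scatter. Nothing available explains the gain.

As far as these compounds go, it remains open which part of the new group carries the step: a plain propylamide, a shorter or longer chain ending in imidazole, or a pyridine ring in place of the imidazole could separate chain from ring. From the compounds shown here alone, whether the same step holds on the core of compound 3 also remains open.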